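Hydroxyphenyl positional swap on a pyridine-type series

The compounds below may be only part of what the source reports. "The series", "measured", "known", "first", "only" and "open" are said of these compounds alone.

Compound 1 `Oc1cccc(-c2cc(-c3ccccc3F)cc(-c3cccc(O)c3)n2)c1` gives 11200 nM in a functional assay on DU-145 cells (Homo sapiens) for inhibition; on this read-out higher numbers stand for weaker inhibition and lower numbers for stronger inhibition. Compound 2 `Oc1ccc(-c2cc(-c3ccccc3F)cc(-c3cccc(O)c3)n2)cc1` gives 3160 nM; the change 4-hydroxyphenyl in place of 3-hydroxyphenyl on an aromatic carbon made a 3.5-fold lower number from compound 1 to compound 2 (0.55 log units; beyond the scatter). Compound 3 `Oc1cccc(-c2cc(-c3ccccc3C(F)(F)F)cc(-c3ccccc3O)n2)c1` gives 7250 nM, within the scatter of compound 1 and a higher number than compound 2; how the core of compound 3 differs from that of compound 1 is not broken down here. Compound 4 `Oc1ccc(-c2cc(-c3ccccc3C(F)(F)F)cc(-c3ccccc3O)n2)cc1` carries the same kind of change, (4-hydroxyphenyl in place of 3-hydroxyphenyl on an aromatic carbon), though the surroundings differ: here the carbon is meta to a 2-(trifluoromethyl)phenyl group and meta to a 2-hydroxyphenyl group, whereas before it was meta to a 2-fluorophenyl group and meta to a 3-hydroxyphenyl group. The expected step is a 3.2-fold lower number from compound 3 to compound 4 (0.50 log units; beyond the scatter), because the same kind of change gave a 3.5-fold lower number from compound 1 to compound 2 (0.55 log units; beyond the scatter). Compound 4 is therefore estimated at 2300 nM, between 900 nM and 6000 nM.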

Compound 4, half-maximal inhibitory concentration: 6690 nM
Compound 4: the middle estimate sits 2.9-fold (0.46 log units) below what was measured; measured number outside the range, above it.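

In this assay, 4-hydroxyphenyl in place of 3-hydroxyphenyl gives a 1.1-fold lower number from compound 3 to compound 4 (0.03 log units; within the scatter), so the lower number seen on the core of compound 1 does not carry over to the core of compound 3: the same change on two cores in this assay, a 3.5-fold lower number (0.55 log units; beyond the scatter) from compound 1 to compound 2 and a 1.1-fold lower number (0.03 log units; within the scatter) from compound 3 to compound 4, 3.3-fold (0.51 log units) apart, beyond the scatter of two such steps

The step therefore cannot be treated as a fixed increment across these two cores. The cores differ in two places, 2-fluorophenyl against 2-(trifluoromethyl)phenyl and 3-hydroxyphenyl against 2-hydroxyphenyl, and these pairs do not show which difference accounts for the gap.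

Among the compounds shown here, open is whether the step returns on a core with only one of those two groups changed. Also open, from the compounds shown here alone, is how an aminophenyl or carboxyphenyl group in place of 4-hydroxyphenyl would read on either core.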